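Methyl and trifluoromethyl steps at the glucagon receptor

The compounds below may be only part of what the source reports. "The series", "measured", "known", "first", "only" and "open" are said of these compounds alone.

Compound 1 `CCCC(Oc1ccc(-n2cccn2)cc1)c1ccc(C(=O)NCCC(=O)O)cc1`, compound 2 `CCCC(Oc1ccc(-n2cc(C)cn2)cc1)c1ccc(C(=O)NCCC(=O)O)cc1` and compound 3 `CCCC(Oc1ccc(-n2cc(C(F)(F)F)cn2)cc1)c1ccc(C(=O)NCCC(=O)O)cc1` share one core. In an assay on cells for displacement of a labelled ligand from Glucagon receptor (Homo sapiens), in the presence of a further agent that is not named here (on this read-out higher numbers stand for weaker inhibition and lower numbers for stronger inhibition), compound 1 gives 4100 nM, compound 2 gives 1900 nM and compound 3 gives 890 nM. The change methyl in place of hydrogen on an aromatic carbon brings a 2.2-fold lower number from compound 1 to compound 2 (0.33 log units; beyond the scatter), and a 2.1-fold lower number from compound 2 to compound 3 (0.33 log units; beyond the scatter) follows. Compound 4 `CCCC(Oc1ccc(-n2cc(C(F)(F)F)cn2)c(C)c1)c1ccc(C(=O)NCCC(=O)O)cc1` is not yet measured; it differs from compound 3 by methyl in place of hydrogen on an aromatic carbon. This is the same kind of change as from compound 1 to compound 2, but the place differs: there the methyl entered a five-membered aromatic ring with 2 nitrogen, here a six-membered aromatic ring of carbon only, ortho to a 4-(trifluoromethyl)-1H-pyrazol-1-yl group and meta to a large group. The two cores differ by trifluoromethyl in place of hydrogen on an aromatic carbon, a change worth a 4.6-fold lower number from compound 1 to compound 3 (0.66 log units; beyond the scatter). For compound 4 the expected step is a 1.8-fold lower number from compound 3 to compound 4 (0.25 log units; within the scatter), resting on a 2.2-fold lower number from compound 1 to compound 2 (0.33 log units; beyond the scatter). Compound 4 is expected to give 500 nM, between 200 nM and 2000 nM.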

Compound 4, inhibition constant in the Glucagon receptor assay: 200 nM
Estimate against measurement, compound 4: 2.5-fold (0.40 log units) above, and the stated range covers the measured number.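

In the Glucagon receptor assay, methyl in place of hydrogen on the six-membered aromatic ring brings a 4.5-fold lower number from compound 3 to compound 4 (0.65 log units; beyond the scatter). In a physicochemical assay for lipophilicity, using the shake flask method, at pH 7.4 (a lower number here means a more polar compound, a higher number a more lipophilic compound), compound 3 gives 2.4 and compound 4 gives 2.6. In the physicochemical assay the same change gives a number 0.20 log units higher from compound 3 to compound 4 (within the scatter). Set beside the earlier methyl step, the new step cannot be told apart from it in size: the same change on two cores in the Glucagon receptor assay, a 2.2-fold lower number (0.33 log units; beyond the scatter) from compound 1 to compound 2 and a 4.5-fold lower number (0.65 log units; beyond the scatter) from compound 3 to compound 4, 2.1-fold (0.31 log units) apart, within the scatter of two such steps. So on both cores methyl lowered the number by similar amounts, but the methyl sits on a different ring in each pair, and two steps do not show that the gain carries over to other places or cores.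

Going by these compounds, whether an ethyl group, a chlorine atom or a methoxy group on the aromatic carbon ortho to the 4-(trifluoromethyl)-1H-pyrazol-1-yl group would act like methyl remains open. So does the effect of this same methyl on the core of compound 1.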